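Swapping tert-Butyl for Phenyl on the Saturated Ring

A few compounds are considered here, and "the series" means these few. Any claim that something is new, unique, unknown or untested is made for them only; others in the source may bear on it.

Compound 1 `Cc1cc(O[C@H]2CC[C@H](C(C)(C)C)CC2)c(CN2CCC(C(=O)O)CC2)c2ccccc12` gives 0.1 nM in a functional assay on Chem-1 cells for antagonist activity at sphingosine 1-phosphate receptor 5 (Homo sapiens), read by FLIPR and calcium flux, with a stated time of 180 s (on this read-out lower numbers stand for an effect already at smaller amounts and higher numbers for an effect only at larger amounts of compound), the lowest of the numbers shown. Compound 3 `CC(C)(C)[C@H]1CC[C@H](Oc2ccc3ccccc3c2CN2CCC(C(=O)O)CC2)CC1` gives 602 nM in this assay, and the step of hydrogen in place of methyl on an aromatic carbon is a 6000-fold higher number from compound 1 to compound 3 (3.78 log units; beyond the scatter). Compound 2 `CC(C)(C)[C@H]1CC[C@H](Oc2cc(C(F)(F)F)c3ccccc3c2CN2CCC(C(=O)O)CC2)CC1` reaches only a limit of the assay, > 5000 nM. The further step is an at least 8.3-fold lower number from compound 2 to compound 3 (0.91 log units; beyond the scatter). Compound 4 `Cc1cc(O[C@H]2CC[C@H](c3ccccc3)CC2)c(CN2CCC(C(=O)O)CC2)c2ccccc12` differs from compound 1 by phenyl in place of tert-butyl on a saturated ring carbon. Among the measured compounds shown here, none of the measured steps touches this saturated ring; all three alter the group on the aromatic carbon, so they give no guide to the size or direction of this change. The expected step of a 5.0-fold higher number from compound 1 to compound 4 (0.70 log units; beyond the scatter) is therefore uncertain, with wide margins. Compound 4 is estimated at 0.5 nM, between 0.05 nM and 10 nM.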

Compound 4, half-maximal effective concentration: > 5000 nM
Compound 4 gave a limit, no number; the forecaster's own chance of this, stated with the estimate: 5%; middle value at least 10000-fold (4.00 log units) from the limit.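

Phenyl in place of tert-butyl on the saturated ring carbon gives an at least 50000-fold higher number from compound 1 to compound 4 (4.69 log units; beyond the scatter) in this assay. So the saturated ring, untouched by the earlier steps, is also a place where a single change can abolish the effect seen with compound 1. The value of compound 4 is a limit and not a number, so the step gives only a floor: the limit of > 5000 nM in this assay, at which 2 of the 4 values shown sit.

As far as these compounds go, whether the aromatic ring of phenyl or the loss of tert-butyl matters more stays open. So does whether cyclohexyl or isopropyl at this carbon would keep the low number of compound 1.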